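Bromo in Place of Hydrogen on the Phenyl Ring

The source may hold more compounds than are shown below. What is called first, only, known or untested is meant among the compounds shown, and "the series" means these compounds.

Measured so far:
Compound 1, `O=C(Nc1cccc(OCc2cn(-c3ccccc3)nn2)c1)Nc1ccc(Cl)c(C(F)(F)F)c1`: 1780 nM
Compound 2, `Cc1ccccc1-n1cc(COc2cccc(NC(=O)Nc3ccc(Cl)c(C(F)(F)F)c3)c2)nn1`: 3440 nM

Both were tested in a functional assay on HepG2 cells (Homo sapiens) for inhibition, read by MTT assay, with a stated time of 72 h; a higher number here means a weaker inhibitor, a lower number a stronger inhibitor. Compound 1 gives the lowest of the two numbers; the nearest is compound 2, and a 1.9-fold higher number from compound 1 to compound 2 (0.29 log units; within the scatter) lies within the scatter. Compound 3, `O=C(Nc1cccc(OCc2cn(-c3ccccc3Br)nn2)c1)Nc1ccc(Cl)c(C(F)(F)F)c1`, remains to be measured. It differs from compound 1 by bromo in place of hydrogen on an aromatic carbon; cut one bond further out, the change reads phenyl to 2-bromophenyl. For the measured compounds named here, the only measured step that bears on it is the one from compound 1 to compound 2, methyl in place of hydrogen on the same aromatic carbon, and that step stayed within the scatter. A bromo on that carbon is therefore expected to give no more than a small rise in the number, not clearly beyond the scatter. Compound 3 is thus estimated at 2500 nM with a range of 1000 nM to 6500 nM. That estimate corresponds to an expected step of a 1.4-fold higher number from compound 1 to compound 3 (0.15 log units; within the scatter).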

Compound 3, half-maximal inhibitory concentration: 2810 nM
Compound 3: the middle estimate sits 1.1-fold (0.05 log units) below what was measured; measured number inside the range.
By their numbers in this assay, from the lowest: compounds 1, 3 and 2 (each within the scatter of the next).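

In this assay bromo in place of hydrogen on this aromatic carbon, ortho to a large group, also stays within the scatter (a 1.6-fold higher number from compound 1 to compound 3 (0.20 log units; within the scatter)), so a second group joins methyl in leaving the number unresolved from that of the unsubstituted phenyl compound. The new exchange of one group for the other, bromo in place of methyl, also stays within the scatter (a 1.2-fold lower number from compound 2 to compound 3 (0.09 log units; within the scatter)), so hydrogen, methyl and bromo at this place cannot be told apart in these three compounds. No accompanying evidence bears on this result.

The compounds shown leave open whether an amine, a carboxylic acid or a longer chain on this carbon would move the number beyond the scatter. They also leave open whether bromo on another carbon of this ring would stay within it.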